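The compounds below may be only part of what the source reports. "The series", "measured", "known", "first", "only" and "open" are said of these compounds alone.

Compound 1 `CC(C)(C)c1ccc(OC(=O)c2cn(-c3ccccc3)nc2-c2ccncc2)cc1` gives 18700 nM in a functional assay on HL-60 cells (Homo sapiens) for cytotoxicity, read by MTT assay, with a stated time of 48 h; on this read-out higher numbers stand for weaker inhibition and lower numbers for stronger inhibition. Compound 2 `Cc1ccc(C(C)C)c(OC(=O)c2cn(-c3ccccc3)nc2-c2ccncc2)c1` gives 17800 nM. Compound 3 `O=C(Oc1ccc2ccccc2c1)c1cn(-c2ccccc2)nc1-c1ccncc1` gives only a limit, > 100000 nM.

Compound 3 thus sits at the weak end of what was measured, reported at the limit (the limit of > 100000 nM in this assay, at which 1 of the 3 values shown sits). The two changes leading to it, an at least 5.3-fold higher number from compound 1 to compound 3 (0.72 log units; beyond the scatter) and an at least 5.6-fold higher number from compound 2 to compound 3 (0.74 log units; beyond the scatter), both went beyond the scatter, whereas a 1.1-fold lower number from compound 1 to compound 2 (0.02 log units; within the scatter) did not. Compound 4 `O=C(O)c1cn(-c2ccccc2)nc1-c1ccncc1` differs from compound 3 by hydrogen in place of naphthalen-2-yl on an oxygen next to a carbonyl group. Within the data shown here, no measured step exchanges the group on that oxygen for hydrogen, and the measured steps show only that altering the group on that oxygen can move the number beyond the scatter. Compound 4 is expected to remain near the limit, with an expected step of a number no higher from compound 3 to compound 4 (the limit leaves the size open). Compound 4 is estimated at 100000 nM, between 30000 nM and 300000 nM.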

Compound 4, half-maximal inhibitory concentration: > 100000 nM
Compound 4 was reported as a limit; the forecaster's own chance of this, stated with the estimate: 70%; the middle value lies on the limit itself.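

In this assay, hydrogen on an oxygen next to a carbonyl group gives an at least 5.6-fold higher number from compound 2 to compound 4 (0.74 log units; beyond the scatter) and an at least 5.3-fold higher number from compound 1 to compound 4 (0.72 log units; beyond the scatter). Hydrogen thus joins naphthalen-2-yl at the weak end, so the readable numbers shown at this place belong only to the 4-(tert-butyl)phenyl and 2-isopropyl-5-methylphenyl groups. Compound 3 and compound 4 are both limits, and the step between them cannot be read: the limit of > 100000 nM in this assay, at which 2 of the 4 values shown sit.

Going by these compounds, it remains open whether a small group on that oxygen, such as methyl or benzyl, would give a readable number. On these data alone, it also remains open how far compound 3 and compound 4 actually differ.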